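The compounds below may be only part of what the source reports. "The series", "measured", "known", "first", "only" and "open" are said of these compounds alone.

Measured compounds, growth-inhibition numbers in a functional assay on A2780 cells (Homo sapiens) for inhibition, read by MTT assay, with a stated time of 72 h; a higher number here means a weaker inhibitor of growth, a lower number a stronger inhibitor of growth:
- compound 1 `O=S(=O)(NCCNCc1cccc2ccccc12)c1cc(C(F)(F)F)cc(C(F)(F)F)c1` gives 21000 nM
- compound 2 `CC(C)(C)c1ccc(CNCCCNS(=O)(=O)c2cc(C(F)(F)F)cc(C(F)(F)F)c2)cc1` gives 2900 nM
- compound 3 `O=S(=O)(NCCNCc1ccc(-c2ccccc2)cc1)c1cc(C(F)(F)F)cc(C(F)(F)F)c1` gives 2600 nM

Compound 2 stands second highest of the three numbers in this assay. Its nearest neighbour is compound 3, whose number sits within the scatter of that of compound 2, so no order between them is read. The furthest is compound 1, whose number is higher by a margin beyond the scatter; compound 1 is the weaker grower-inhibitor of the pair.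

Compound 4 `O=S(=O)(NCCCNCC1COc2ccccc2O1)c1cc(C(F)(F)F)cc(C(F)(F)F)c1` is not yet measured in this assay. It comes from compound 2 by a single change: 2,3-dihydro-1,4-benzodioxin-2-yl in place of 4-(tert-butyl)phenyl on a saturated chain carbon bound to an amine nitrogen. The common core, the sulfonamide and the three-carbon chain to the amine nitrogen are kept.

For the measured compounds named here, no measured pair isolates this kind of swap, so the size of the step rests on expectation alone. The group that enters replaces an all-carbon aromatic ring by a fused bicyclic unit bearing two acceptors; the only other variation shown, compound 1 against compound 3, spans both ring and chain length and is not a clean guide. A modest weakening relative to compound 2 is expected, the step from compound 2 to compound 4 estimated at a 2.1-fold higher number from compound 2 to compound 4 (0.32 log units; beyond the scatter). Compound 4 is therefore expected to give about 6000 nM in this assay, with a likely range from 2000 nM to 20000 nM.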

Compound 4, concentration for 50% growth inhibition: 1500 nM
Compound 4: middle estimate off by 4.0-fold (0.60 log units), on the high side, outside the stated range (below it).
By their numbers in this assay, from the lowest: compounds 4, 3 and 2 (each within the scatter of the next); then compound 1.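

In this assay, placing 2,3-dihydro-1,4-benzodioxin-2-yl in place of 4-(tert-butyl)phenyl on a saturated chain carbon bound to an amine nitrogen gives a 1.9-fold lower number from compound 2 to compound 4 (0.29 log units; within the scatter), so the two groups are not told apart at this place. For the compounds shown here, this is the first step that isolates a single change, and it shows that an all-carbon group carrying no hydrogen-bond acceptors can give way to a fused ring unit with oxygen atoms and hydrogen-bond acceptors without a shift beyond the usual scatter of this read-out. No independent measurement bears on why these two groups read alike, so the result stands as an observation only.

Still open, as far as these compounds go, is how far this tolerance extends, for example to a carboxylic acid or a morpholine ring at the same place, as both groups compared here carry no net charge. Also open is whether the same swap reads alike on a longer chain, or with a carbonyl on the amine nitrogen, since the compounds shown hold neither feature.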